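The source may report more compounds than this note shows. Statements on the series, on what has been measured and on what is new or still open speak of the compounds shown alone.

Measured compounds:
- compound 1, `OC[C@H]1OC(n2cnc3c(-c4ccc(Cl)cc4)ncnc32)[C@H](O)[C@@H]1O`: 5000 nM
- compound 2, `Cc1csc(-c2ncnc3c2ncn3C2O[C@H](CO)[C@@H](O)[C@H]2O)c1`: 11400 nM

Both measured compounds were tested in a functional assay on HeLa cells (Homo sapiens) for inhibition; on this read-out lower numbers stand for stronger inhibition and higher numbers for weaker inhibition. Compound 1 gives 5000 nM in this assay, and compound 2 gives 11400 nM. Among these two numbers compound 2 has the higher one, and the step between them is a 2.3-fold higher number from compound 1 to compound 2 (0.36 log units; beyond the scatter).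

Compound 3, `OC[C@H]1OC(n2cnc3c(-c4ccc(F)cc4)ncnc32)[C@H](O)[C@@H]1O`, has not yet been measured. It differs from compound 2 in one place: 4-fluorophenyl in place of 4-methylthiophen-2-yl on an aromatic carbon. Among the compounds with values here, the only step seen so far that touches this same place is the one from compound 1 to compound 2, where a 4-methylthiophen-2-yl group replaced a 4-chlorophenyl group and the number rose by a 2.3-fold higher number from compound 1 to compound 2 (0.36 log units; beyond the scatter). The change to compound 3 goes the opposite way, back to a six-membered carbon ring, now carrying fluorine instead of chlorine. In this assay the step from compound 2 to compound 3 is therefore expected to be a 1.9-fold lower number from compound 2 to compound 3 (0.28 log units; within the scatter), a lower number, because compound 1 with its 4-chlorophenyl group gave 5000 nM. Within the data shown here, no measured step tells how fluorine compares with chlorine here, so the range stays wide. Compound 3 is estimated at 6000 nM, between 2500 nM and 15000 nM.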

Compound 3, half-maximal inhibitory concentration: 2700 nM
For compound 3 the middle estimate is 2.2-fold (0.35 log units) above the measured one, within the range that was stated.
By their numbers in this assay, from the lowest: compounds 3 and 1 (each within the scatter of the next); then compound 2.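

In this assay the change to 4-fluorophenyl on this aromatic carbon gives a 4.2-fold lower number from compound 2 to compound 3 (0.63 log units; beyond the scatter) and so moves the number the opposite way to a 2.3-fold higher number from compound 1 to compound 2 (0.36 log units; beyond the scatter). Each of the two halogen-bearing phenyl groups now has a step beyond the scatter from the 4-methylthiophen-2-yl group, so among these three compounds, compound 2 stands apart, with no compound going against this. The exchange of the halogen itself gives a 1.9-fold lower number from compound 1 to compound 3 (0.27 log units; within the scatter) and therefore does not separate fluoro from chloro at this position in this read-out. No supporting data accompany these numbers to explain these differences.

From the compounds shown here alone, all three compounds carry an aromatic ring on this carbon and are otherwise identical, so it remains open how a phenyl ring with no halogen, a methoxy group on the phenyl ring, or a non-aromatic group such as an amine or a longer alkyl chain would compare. A single thiophene example also cannot show whether the higher number of compound 2 belongs to the five-membered ring, to its sulfur or to its methyl group.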